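One Side-Chain Swap on a Kinase Inhibitor

The source may hold more compounds than are shown below. What is called first, only, known or untested is meant among the compounds shown, and "the series" means these compounds.

In an assay on isolated protein for inhibition of protein kinase C theta type (Homo sapiens), read by TR-FRET, with a stated time of 2 h (on this read-out lower numbers stand for stronger inhibition and higher numbers for weaker inhibition), compound 1 `CO[C@H]1CC[C@@H](Nc2cc(NCc3cnccc3C(F)(F)F)ncc2C#N)CC1` gives 58 nM.
In this assay compound 2 `CO[C@H]1CC[C@@H](CNc2cc(NCc3cnccc3C(F)(F)F)ncc2C#N)CC1` gives 70 nM.

Going by the values given here, compound 2 has the higher of the two numbers, yet the only measured step, a 1.2-fold higher number from compound 1 to compound 2 (0.08 log units; within the scatter), lies within the scatter, so the two compounds cannot be told apart. Compound 3 `N#Cc1cnc(NCc2cnccc2C(F)(F)F)cc1NCCC1CCOCC1` differs from compound 2 by (oxan-4-yl)methyl in place of 4-methoxycyclohexyl on a saturated chain carbon bound to a nitrogen on an aromatic ring. Among the compounds with values here, no measured step bears directly on this change; the one step available shows that lengthening the link on the ring nitrogen changed little. On that basis the step of a 1.3-fold higher number from compound 2 to compound 3 (0.11 log units; within the scatter) is expected to stay within the scatter, and compound 3 is estimated at 90 nM, between 35 nM and 230 nM.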

Compound 3, half-maximal inhibitory concentration: 1200 nM
Compound 3: middle estimate off by 13-fold (1.12 log units), on the low side; the whole stated range lies below it.
By their numbers in this assay, from the lowest: compounds 1 and 2 (each within the scatter of the next); then compound 3.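

In this assay, (oxan-4-yl)methyl in place of 4-methoxycyclohexyl brings a 17-fold higher number from compound 2 to compound 3 (1.23 log units; beyond the scatter) and, measured against the shorter side chain, 2-(oxan-4-yl)ethyl brings a 21-fold higher number from compound 1 to compound 3 (1.32 log units; beyond the scatter) on the same nitrogen. This position is therefore sensitive to the side chain, even though the first change made no measurable difference. Nothing measured here explains the loss.

These compounds cannot separate the effect of the oxane ring from that of the longer link. A 2-(4-methoxycyclohexyl)ethyl group would keep the ring and lengthen the link, whereas oxan-4-yl on the nitrogen would change the ring and keep the link short.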